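A few compounds are considered here, and "the series" means these few. Any claim that something is new, unique, unknown or untested is made for them only; others in the source may bear on it.

Three compounds share one core and differ only in the ring attached to a nitrogen on an aromatic ring. Compound 1 `COc1cc2ncnc(Nc3ccc(F)c(Cl)c3)c2cc1OCCCCC(=O)Nc1ccc(S(N)(=O)=O)cc1` carries a 3-chloro-4-fluorophenyl group there, compound 2 `COc1cc2ncnc(Nc3cccc(Br)c3)c2cc1OCCCCC(=O)Nc1ccc(S(N)(=O)=O)cc1` a 3-bromophenyl group, and compound 3 `COc1cc2ncnc(Nc3ccc(Cl)cc3)c2cc1OCCCCC(=O)Nc1ccc(S(N)(=O)=O)cc1` a 4-chlorophenyl group. In a functional assay on A-431 cells (Homo sapiens) for antiproliferative activity, read by MTT assay, with a stated time of 72 h (a higher number here means a weaker inhibitor, a lower number a stronger inhibitor), compound 1 gives 5020 nM. Compound 2 gives 9750 nM in the same test, and compound 3 gives 7120 nM. All three numbers lie within the usual scatter of one another: the step of a 1.4-fold higher number from compound 1 to compound 3 (0.15 log units; within the scatter) and the step of a 1.4-fold lower number from compound 2 to compound 3 (0.14 log units; within the scatter) are both small, as is a 1.9-fold higher number from compound 1 to compound 2 (0.29 log units; within the scatter). Compound 3 therefore stands among its neighbours without separating from either.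

Compound 4 `COc1cc2ncnc(Nc3cc(F)c(F)c(F)c3)c2cc1OCCCCC(=O)Nc1ccc(S(N)(=O)=O)cc1` takes the same route one more time: 3,4,5-trifluorophenyl in place of 4-chlorophenyl on a nitrogen on an aromatic ring. Every exchange of this ring that has been measured so far left the number where it was, so there is no reason from these data to expect the new ring to act differently. The expected step of a 1.0-fold lower number from compound 3 to compound 4 (0.01 log units; within the scatter) is therefore no larger than the scatter, in no particular direction. For compound 4 the estimate in this assay is 7000 nM, with a likely range from 3000 nM to 16000 nM.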

Compound 4, half-maximal inhibitory concentration: 23400 nM
Compound 4: middle estimate off by 3.3-fold (0.52 log units), on the low side; the measured number lies above the stated range.
By their numbers in this assay, from the lowest: compounds 1, 3 and 2 (each within the scatter of the next); then compound 4.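

Earlier exchanges of this ring all stayed within the scatter, which made the position look indifferent to the ring attached there. Going by these compounds alone, the 3,4,5-trifluorophenyl group breaks that picture: in this assay it is the first ring to separate from the others, with steps beyond the scatter against all three (in turn a 3.3-fold higher number from compound 3 to compound 4 (0.52 log units; beyond the scatter) and a 2.4-fold higher number from compound 2 to compound 4 (0.38 log units; beyond the scatter) and a 4.7-fold higher number from compound 1 to compound 4 (0.67 log units; beyond the scatter)), so compound 4 is the weakest of the four and the ring's identity can matter here. Among these four, it is also the only ring with no chlorine or bromine, yet nothing available explains the change.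

With a single such compound, the compounds shown leave open whether the step follows from the absence of chlorine and bromine or from this particular set of fluorines, given that compound 1 also carries a fluorine and shows no such rise. A plain phenyl ring, or a phenyl ring bearing only one fluorine, a methyl group or a methoxy group, would help separate these readings.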